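The source may report more compounds than this note shows. Statements on the series, on what has been measured and on what is new or still open speak of the compounds shown alone.

Within the data shown here, compound 2 `COc1cc2cc(Oc3ccc(NC(=O)Nc4ccc(Cl)c(C(F)(F)F)c4)cc3)c(C)nc2cc1OC` is one of two compounds measured in a functional assay on HT-29 cells (Homo sapiens) for inhibition, read by sulforhodamine B assay, with a stated time of 48 h; a higher number here means that more compound is tolerated, a lower number that less compound is tolerated. In this assay compound 2 gives 14200 nM, the lowest of the two numbers, though the nearest number, from compound 1 `COc1cc2cc(Oc3ccc(NC(=O)Nc4cccc(C(F)(F)F)c4)cc3)c(C)nc2cc1OC`, lies within the scatter: in this assay compound 1 gives 17800 nM. The change from compound 2 to compound 3 `COc1cc2cc(Oc3ccc(NC(=O)Nc4ccc(Cl)c(Cl)c4)cc3)c(C)nc2cc1OC` is chloro in place of trifluoromethyl on an aromatic carbon. Among the measured compounds shown here, only one measured step bears on it, as it also alters the same ring: a 1.3-fold lower number from compound 1 to compound 2 (0.10 log units; within the scatter). That step, an added chloro on this ring, stayed within the scatter, so a swap of one small halogen-bearing group for another on the same ring is expected to move the number little, in no clear direction. The estimate for compound 3 in this assay is therefore 15000 nM, with a range from 6000 nM to 38000 nM, an expected step of a 1.1-fold higher number from compound 2 to compound 3 (0.02 log units; within the scatter).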

Compound 3, concentration lethal to 50% of the cells: 10600 nM
Compound 3: the middle estimate sits 1.4-fold (0.15 log units) above what was measured; low and high end bracket the measured number.
By their numbers in this assay, from the lowest: compounds 3, 2 and 1 (each within the scatter of the next).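

In this assay, trifluoromethyl and chloro on this aromatic carbon cannot be told apart: the swap gives a 1.3-fold lower number from compound 2 to compound 3 (0.13 log units; within the scatter) and stays within the usual scatter. The wider change, 3,4-dichlorophenyl in place of 3-(trifluoromethyl)phenyl, gives a 1.7-fold lower number from compound 1 to compound 3 (0.23 log units; within the scatter) and also stays within the scatter, so no order among the three compounds can be claimed from this read-out. Nothing at hand explains these numbers.

The compounds shown leave open whether a group of a different kind on this carbon, such as an amine, a carboxylic acid or a nitrile, would move the number beyond the scatter. They also leave open whether the swap from trifluoromethyl to chloro would read the same without the chloro group ortho to this carbon.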